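The source may report more compounds than this note shows. Statements on the series, on what has been measured and on what is new or still open speak of the compounds shown alone.

Measured so far:
compound 1, `CCOc1ccccc1-c1ccc(-c2nc3cnccc3c(N[C@@H]3CCOC3=O)c2C#N)cc1`: 2.7
compound 2, `CC[C@@H](Nc1c(C#N)c(-c2ccc(-c3ccc(Cl)cc3)cc2)nc2cnccc12)C(N)=O`: 3.1

In a physicochemical assay for lipophilicity, read by HPLC, at pH 7.5 (on this read-out higher numbers stand for higher lipophilicity and lower numbers for lower lipophilicity), compound 1 gives 2.7, the lower of the two numbers; compound 2 gives 3.1, and the gap between them is beyond the scatter. Going by the values given here, no step between measured compounds differs in one place only, so nothing about this change has been measured directly.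

Compound 3, `CCOc1ccccc1-c1ccc(-c2nc3cnccc3c(C[C@H](C)C(N)=O)c2C#N)cc1`, differs from compound 1 thus: 2-carbamoylpropyl in place of (2-oxooxolan-3-yl)amino on an aromatic carbon. With an amide already present in compound 2 at 3.1, a modest rise is expected: the step of a number 0.40 log units higher from compound 1 to compound 3 (beyond the scatter) is estimated beyond the scatter. Compound 3 is expected at 3.1, within 2.6 to 3.6.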

Compound 3, distribution coefficient: 3
Compound 3: the middle estimate sits 0.10 log units above what was measured, and the stated range covers the measured number.
By their numbers in this assay, from the lowest: compounds 1, 3 and 2 (each within the scatter of the next, the first and the last beyond it).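

In this assay, 2-carbamoylpropyl in place of (2-oxooxolan-3-yl)amino on this aromatic carbon, ortho to a cyano group, gives a number 0.30 log units higher from compound 1 to compound 3 (within the scatter), the first one-place step read in the series. This position therefore accepts the loss of the five-membered non-aromatic ring and the open 2-carbamoylpropyl chain, with the two compounds staying within the scatter of each other. Nothing at hand accounts for this step.

Still open, going by these compounds, is whether a carboxylic acid or a longer chain at this position would stay within the scatter of compound 1. A single step also cannot show whether this result carries over to other groups on the shared core.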